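Chloro to tert-Butyl: What Compound 4 Might Show

The source may report more compounds than this note shows. Statements on the series, on what has been measured and on what is new or still open speak of the compounds shown alone.

Compound 1 `Nc1ccccc1NC(=O)c1ccc(CSc2nccc(C(F)(F)F)n2)cc1`: 80.1%
Compound 2 `Nc1ccccc1NC(=O)/C=C/c1ccc(CSc2ccc(Cl)cc2)cc1`: 48.2%
Compound 3 `Nc1ccccc1NC(=O)c1ccc(CSc2ccc(C(F)(F)F)cn2)cc1`: 5.34%

All three compounds were tested in a functional assay on A-375 cells (Homo sapiens) for inhibition, read by CCK-8 assay, with a stated time of 72 h, tested at 8 uM; on this read-out higher numbers stand for more inhibition of growth at the one concentration tested and lower numbers for less inhibition of growth. Compound 2 stands second highest of the three: compound 1 lies above it, beyond the usual scatter, and compound 3 lies far below it, also beyond the scatter. Compound 4 `CC(C)(C)c1ccc(SCc2ccc(/C=C/C(=O)Nc3ccccc3N)cc2)cc1` differs from compound 2 in one place: tert-butyl in place of chloro on an aromatic carbon. Going by the values given here, no measured pair shows this particular change, so its effect here is unknown. The step of a number 2.2 percentage points lower from compound 2 to compound 4 (within the scatter) is expected to stay within the scatter, in no clear direction. Compound 4 is therefore estimated to give 46%, with a likely range from 22% to 70%.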

Compound 4, percent growth inhibition at one concentration: 35.5%
Compound 4: middle estimate off by 10.5 percentage points, on the high side; low and high end bracket the measured number.
By their numbers in this assay, from the lowest: compound 3; then compound 4; then compound 2; then compound 1.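

In this assay, going by these compounds alone, tert-butyl in place of chloro gives the first comparison in this set that changes only one place, a step of a number 12.7 percentage points lower from compound 2 to compound 4 (beyond the scatter) on a ring position para to a large group. What sits at this position therefore matters, although compound 4, with four heavy atoms there instead of one, still inhibits growth. Nothing available explains this drop.

Still open, on these data alone, is where a methyl group, a methoxy group or an amine at this position would fall. A single step cannot establish a trend across groups.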